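This account rests on a few compounds, and the source may have more. Where it says the series, first, only, none or still open, it means among the compounds named here.

For the measured compounds named here, compound 2 `O=C(Nc1cccc2cnccc12)NC1CCc2cc(F)ccc2C1CC1CC1` gives 0.8 nM in an assay on HEK293 cells for displacement of a labelled ligand from transient receptor potential cation channel subfamily V member 1 (Homo sapiens) (on this read-out higher numbers stand for weaker inhibition and lower numbers for stronger inhibition), the lower of the two numbers measured so far, with compound 1 `O=C(Nc1cccc2cnccc12)NC1CCc2cc(F)ccc2C1Cc1ccoc1` next to it at 16 nM. Compound 3 `O=C(Nc1cccc2cnccc12)NC1CCc2cc(F)ccc2C1Cc1ccc(C(F)(F)F)cc1` carries 4-(trifluoromethyl)phenyl in place of cyclopropyl on a saturated chain carbon bound to a saturated ring carbon. Going by the values given here, the one measured step that bears on this position, a 20-fold lower number from compound 1 to compound 2 (1.30 log units; beyond the scatter), shows that an aromatic ring at this carbon went with a much higher number than cyclopropyl. Returning to an aromatic ring in compound 3 is therefore expected to raise the number, a step of about a 13-fold higher number from compound 2 to compound 3 (1.10 log units; beyond the scatter). Compound 3 is estimated at 10 nM, within a range of 2 nM to 60 nM.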

Compound 3, inhibition constant: 1 nM
Compound 3: middle estimate off by 10-fold (1.00 log units), on the high side; measured number below the stated range.
By their numbers in this assay, from the lowest: compounds 2 and 3 (each within the scatter of the next); then compound 1.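

Among the compounds shown, an aromatic ring on this carbon does not by itself bring a high number in this assay: replacing cyclopropyl with the much larger 4-(trifluoromethyl)phenyl gives a 1.3-fold higher number from compound 2 to compound 3 (0.10 log units; within the scatter). The high number thus stays with furan-3-yl alone among these three groups, and replacing it with 4-(trifluoromethyl)phenyl gives a 16-fold lower number from compound 1 to compound 3 (1.20 log units; beyond the scatter).

From the compounds shown here alone, how an amine, a longer chain or an unsubstituted phenyl would read at this carbon stays open. Nothing available gives a reason for the gap between furan-3-yl and the other two groups.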